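This account rests on a few compounds, and the source may have more. Where it says the series, first, only, none or still open, it means among the compounds named here.

Measured compounds:
compound 1, `CCCCCCCCCCCCCCNC(=O)[C@H](CO)/N=C/c1ccc([N+](=O)[O-])cc1`, 217000 nM
compound 2, `CCCCCCCCCCCCCCNC(=O)[C@H](CO)/N=C/c1cccc([N+](=O)[O-])c1`, 104000 nM
compound 3, `CCCCCCCCCCCCCCNC(=O)[C@H](CO)/N=C/c1ccc(Cl)cc1`, 27500 nM

All three were tested in a functional assay on cells (Homo sapiens) for cytotoxicity, read by MTT assay, with a stated time of 24 h; a lower number here means a stronger inhibitor, a higher number a weaker inhibitor. Compound 3 has the lowest number of the three: the step of a 7.9-fold lower number from compound 1 to compound 3 (0.90 log units; beyond the scatter) and the step of a 3.8-fold lower number from compound 2 to compound 3 (0.58 log units; beyond the scatter) both favour it beyond the scatter, and the step of a 2.1-fold lower number from compound 1 to compound 2 (0.32 log units; beyond the scatter) separates the other two. Compound 4, `CCCCCCCCCCCCCCNC(=O)[C@H](CO)NCc1ccccc1O`, has not been measured yet. It differs from compound 3 by the change (a group of 9 heavy atoms (7 carbon, 1 nitrogen, 1 oxygen; one six-membered aromatic ring of carbon only) in place of a group of 9 heavy atoms (7 carbon, 1 nitrogen, 1 chlorine; one six-membered aromatic ring of carbon only), on a saturated chain carbon bound to a carbonyl carbon and a saturated chain carbon). Within the data shown here, no measured step matches this change: the two steps that reach compound 3 exchange one substituent on the aromatic ring for another, or move it, and both are modest in size. The change to compound 4 is larger in kind, since the group that enters carries two hydrogen-bond donors and the double bond outside the ring is lost. Among the measured compounds shown here, with only modest steps to draw on and no direct precedent, a modest step in either direction is expected, of the size a 1.5-fold higher number from compound 3 to compound 4 (0.16 log units; within the scatter). For compound 4 the expected value is therefore 40000 nM, in a range from 15000 nM to 120000 nM.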

Compound 4, half-maximal inhibitory concentration: 75300 nM
The estimate for compound 4 lay 1.9-fold (0.27 log units) below the measured number; the range from low to high includes it.
By their numbers in this assay, from the lowest: compound 3; then compounds 4 and 2 (each within the scatter of the next); then compound 1.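

In this assay, a 2.7-fold higher number from compound 3 to compound 4 (0.44 log units; beyond the scatter) shows that swapping the whole group on the saturated chain carbon bound to a carbonyl carbon and a saturated chain carbon weakens the compound, but only modestly. The earlier steps shown here changed only the substituent on the aromatic ring and kept the double bond to nitrogen, whereas this one removes that double bond and also replaces the chloro with a hydroxyl, so a single step carries two changes that cannot be told apart. No measurement here explains the shift in either structural or physical terms. The compounds shown leave open which of the two changes accounts for the step. A benzylamino group carrying chloro instead of hydroxyl would keep the ring substituent of compound 3 while losing only the double bond.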